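The source may hold more compounds than are shown below. What is called first, only, known or untested is meant among the compounds shown, and "the series" means these compounds.

In a functional assay on MIA PaCa-2 cells (Homo sapiens) for inhibition, read by MTT assay, with a stated time of 48 h (on this read-out lower numbers stand for stronger inhibition of growth and higher numbers for weaker inhibition of growth), compound 1 `CN1CC[C@H](c2c(O)cc(O)c3c(=O)cc(/C=C/c4ccccc4)oc23)[C@H](O)C1` gives 2000 nM, compound 2 `CN1CC[C@H](c2c(O)cc(O)c3c(=O)cc(/C=C/c4ccc(Cl)cc4)oc23)[C@H](O)C1` gives 2000 nM and compound 3 `CN1CC[C@H](c2c(O)cc(O)c3c(=O)cc(/C=C/c4c(F)c(F)c(F)c(F)c4F)oc23)[C@H](O)C1` gives 1000 nM. These three values lie within the usual scatter of one another, so compound 3 cannot be told apart from the other two. Compound 4 `CN1CC[C@H](c2c(O)cc(O)c3c(=O)cc(/C=C/c4cccc(F)c4)oc23)[C@H](O)C1` keeps the shared core and changes one group: 3-fluorophenyl in place of 2,3,4,5,6-pentafluorophenyl on a double-bonded chain carbon bound to a double-bonded chain carbon. Three measured steps swap a group at this same place: no change at the digits printed from compound 1 to compound 2 (within the scatter), a 2.0-fold lower number from compound 1 to compound 3 (0.30 log units; within the scatter) and a 2.0-fold lower number from compound 2 to compound 3 (0.30 log units; within the scatter). All three stay within the scatter, so no step beyond it is expected in this assay here. The expected step is a 1.5-fold higher number from compound 3 to compound 4 (0.18 log units; within the scatter), which also stays within the scatter. For compound 4 the estimated value is 1500 nM, with an expected range of 700 nM to 3500 nM.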

Compound 4, concentration for 50% growth inhibition: 2000 nM
The estimate for compound 4 lay 1.3-fold (0.12 log units) below the measured number; the measured number falls inside the stated range.
By their numbers in this assay, from the lowest: compounds 3, 1, 2 and 4 (each within the scatter of the next).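

With 3-fluorophenyl at this place, the number in this assay cannot be told apart from those of the three earlier groups (a 2.0-fold higher number from compound 3 to compound 4 (0.30 log units; within the scatter)), (no change at the digits printed from compound 2 to compound 4 (within the scatter)) and (no change at the digits printed from compound 1 to compound 4 (within the scatter)). A single fluoro on the phenyl ring thus adds a fourth group at this place with no step beyond the scatter, so these four aryl groups remain interchangeable in this read-out. No measured evidence is available to explain this. As far as these compounds go, whether an amine or a carboxylic acid on the phenyl ring, or a longer chain in its place, would move the number beyond the scatter stays open.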